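Ether side chain swap: from oxolane to thiophene ethyl

This account rests on a few compounds, and the source may have more. Where it says the series, first, only, none or still open, it means among the compounds named here.

Measured compounds:
- Compound 1 `Cc1nc(C)c([C@H](OC(C)(C)C)C(=O)O)c(N2CCC(C)(C)CC2)c1-c1ccc(SCCc2ccc(F)cc2)cc1` in an ADME assay on microsomes from liver (Homo sapiens) for metabolic stability, read by LC-MS, tested at 0.5 uM (on this read-out lower numbers stand for a shorter-lived compound and higher numbers for a longer-lived compound), gives > 2 h, a limit of this assay rather than a number.
- Compound 2 `Cc1nc(C)c([C@H](OC(C)(C)C)C(=O)O)c(N2CCC(C)(C)CC2)c1-c1ccc(OC2COCC2c2ccc(F)cc2)cc1` in this assay gives 0.783 h.

For the measured compounds named here, compound 2 holds the only numerical value in this assay; the other result, for compound 1, sits at the limit of > 2 h in this assay, at which 1 of the 2 values shown sits. Compound 3 `Cc1ccc(CCOc2ccc(-c3c(C)nc(C)c([C@H](OC(C)(C)C)C(=O)O)c3N3CCC(C)(C)CC3)cc2)s1` is not yet measured. It differs from compound 2 by 2-(5-methylthiophen-2-yl)ethyl in place of 4-(4-fluorophenyl)oxolan-3-yl on an oxygen on an aromatic ring. Going by the values given here, no step between measured compounds is available, so the size of the change from compound 2 to compound 3 can only be estimated from the two values shown. Among the compounds with values here, since the only numbered value, that of compound 2, is short and the limit for compound 1 is the other outcome, a moderate lengthening is expected, giving an estimated step of a 1.8-fold higher number from compound 2 to compound 3 (0.25 log units; within the scatter). For compound 3 the expected half-life in this assay is 1.4 h, with a range from 0.6 h to 3 h.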

Compound 3, half-life: > 2 h
Compound 3 ended at the assay's limit; the forecaster's own chance of this, stated with the estimate: 35%; middle value at least 1.4-fold (0.15 log units) away from the limit.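

In this assay, for the compounds shown here, the swap on the oxygen on an aromatic ring gives the first readable step at this place: an at least 2.5-fold higher number from compound 2 to compound 3 (0.40 log units; beyond the scatter). This step lies beyond the scatter, so an ether link at this place does not by itself fix a short half-life; the group carried on the oxygen matters. The result for compound 3 is a limit, so the size of this step is only a lower bound, and the step between compound 1 and compound 3 cannot be read: the limit of > 2 h in this assay, at which 2 of the 3 values shown sit.

The change replaces both rings and the chain at once, so the compounds shown do not tell whether the thiophene, its methyl group or the ethyl chain carries the step. A plain 2-(4-fluorophenyl)ethyl on the same oxygen would separate these parts.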